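The compounds below may be only part of what the source reports. "The series", "measured", "known", "first", "only" and "open" are said of these compounds alone.

In an ADME assay on L6 cells (Rattus norvegicus) for cytotoxicity (a higher number here means a weaker inhibitor, a lower number a stronger inhibitor), compound 2 (`CCc1ccc(C(=O)CC(=O)C2CCOCC2)cc1`) gives 202000 nM and compound 3 (`CCc1ccc(-c2cc(C3CCOCC3)[nH]n2)cc1`) gives 165000 nM, two numbers within the usual scatter of each other. Compound 1 (`c1ccc(Oc2ccc(-c3cc(N4CCNCC4)[nH]n3)cc2)cc1`) gives 18000 nM, a clearly lower number, so compound 2 shares the high end of this small set with compound 3. Compound 4 (`O=C(CC(=O)C1CCOCC1)c1ccc(Oc2ccccc2)cc1`) differs from compound 2 in one place: phenoxy in place of ethyl on an aromatic carbon, with phenoxy in place of ethyl on an aromatic carbon. For the measured compounds named here, no measured pair shows this change alone. Compound 1 also carries phenoxy and stands at 18000 nM, so a lower number beyond the scatter is expected in this assay. The expected change is a 3.4-fold lower number from compound 2 to compound 4 (0.53 log units; beyond the scatter). For compound 4 the estimated value is 60000 nM, with an expected range of 20000 nM to 150000 nM.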

Compound 4, half-maximal inhibitory concentration: 231000 nM
Compound 4: middle estimate off by 3.9-fold (0.59 log units), on the low side; measured number above the stated range.
By their numbers in this assay, from the lowest: compound 1; then compounds 3, 2 and 4 (each within the scatter of the next).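

In this assay, putting phenoxy in place of ethyl on this aromatic carbon, para to a large group, gives a 1.1-fold higher number from compound 2 to compound 4 (0.06 log units; within the scatter), a step within the scatter. On this core, then, a group with an extra aromatic ring leaves the number where it was, so carrying phenoxy is not enough on its own to bring a clearly lower number. Nothing available here explains this result.

Going by these compounds, whether an amine or a carboxylic acid at this position would move the number remains open. So does whether phenoxy would behave the same way on the core of compound 1.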